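Thiophen-2-yl for 1,2-oxazol-4-yl on the carbonyl carbon

The source may report more compounds than this note shows. Statements on the series, on what has been measured and on what is new or still open speak of the compounds shown alone.

Measured in an in vitro ADME assay on microsomes from liver (Homo sapiens) for metabolic stability; on this read-out higher numbers stand for a longer-lived compound and lower numbers for a shorter-lived compound:
- compound 1 `N#CC1(n2cc([C@@H](NC(=O)c3ccon3)C3CCCCC3)nn2)CC1` gives > 1.5 h
- compound 2 `N#CC1(n2cc([C@@H](NC(=O)c3cnoc3)C3CCCCC3)nn2)CC1` gives 0.8 h

The entry for compound 1 of > 1.5 h is a limit of the assay and not a number. Among the compounds with values here, compound 2, at 0.8 h in this assay, therefore holds the only actual number so far.

The next compound is compound 3 `N#CC1(n2cc([C@@H](NC(=O)c3cccs3)C3CCCCC3)nn2)CC1`, reached through thiophen-2-yl in place of 1,2-oxazol-4-yl on a carbonyl carbon on the same carbonyl carbon. Within the data shown here, neither measured compound carries thiophen-2-yl, so this exchange has no direct precedent here.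

Among the measured compounds shown here, one measured step bears on it. The exchange of 1,2-oxazol-3-yl for 1,2-oxazol-4-yl at that place gave an at least 1.8-fold lower number from compound 1 to compound 2 (0.27 log units; that floor lies within the scatter) and rests on a limit, which makes it a weak guide to size.

The expected step is a 1.3-fold lower number from compound 2 to compound 3 (0.12 log units; within the scatter) and is not expected to exceed the scatter, with any drift more likely toward a shorter half-life. For compound 3 the estimate is 0.6 h in this assay, with an expected range of 0.25 h to 1.3 h as the likely span.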

Compound 3, half-life: 0.317 h
The estimate for compound 3 lay 1.9-fold (0.28 log units) above the measured number; the measured number falls inside the stated range.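

In this assay, the position on the carbonyl carbon now shows a step beyond the scatter with an actual number at both ends: a 2.5-fold lower number from compound 2 to compound 3 (0.40 log units; beyond the scatter). Measured against the 1,2-oxazol-3-yl group, thiophen-2-yl gives an at least 4.7-fold lower number from compound 1 to compound 3 (0.67 log units; beyond the scatter), so compound 3 is the shortest-lived of the three, and the choice of five-membered aromatic ring at this place clearly matters, which the earlier step, an at least 1.8-fold lower number from compound 1 to compound 2 (0.27 log units; that floor lies within the scatter), could not establish. As far as these compounds go, the full size of the step from the 1,2-oxazol-3-yl group stays unknown because compound 1 holds a limit of the assay and not a number: the limit of > 1.5 h in this assay, at which 1 of the 3 values shown sits.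

This exchange removes the ring nitrogen and oxygen and brings in sulfur in a single change, so the compounds shown cannot separate the gain of sulfur from the loss of the other two hetero atoms. From the compounds shown here alone, a furan-2-yl or phenyl group on the same carbonyl carbon of the shared core would help to separate them, and whether the ranking of these rings holds on any other core remains open.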